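Aryl thiocarbamate series: methylsulfanyl on the aromatic ring

The compounds below may be only part of what the source reports. "The series", "measured", "known", "first", "only" and "open" are said of these compounds alone.

Among the compounds with values here, in a functional assay on GC3/C1 cells (Homo sapiens) for cytotoxicity, read by MTT assay, with a stated time of 6 days (a lower number here means a stronger inhibitor, a higher number a weaker inhibitor), compound 2 `CC(=O)N[C@@H](CSC(=O)Nc1ccccc1)C(=O)O` gives 178000 nM, the only actual number so far. Compound 1 `CC(=O)N[C@@H](CSC(=O)Nc1ccccc1Cl)C(=O)O` reads > 200000 nM, and this is a limit of this assay, not a number.

Compound 3 `CSc1ccccc1NC(=O)SC[C@H](NC(C)=O)C(=O)O` differs from compound 2 as follows: methylsulfanyl in place of hydrogen on an aromatic carbon. This puts methylsulfanyl in place of hydrogen on an aromatic carbon, ortho to a large group.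

Within the data shown here, one measured step bears on this change, and it also concerns a substituent on an aromatic carbon: an at least 1.1-fold lower number from compound 1 to compound 2 (0.05 log units; that floor lies within the scatter). There, hydrogen takes the place of chloro. On these data alone, compound 1 has no number, so the true size of that step stays open. Among the measured compounds shown here, the data hold no measured step for methylsulfanyl itself.

With so little to go on, no step beyond the scatter is expected in this assay, in either direction, though a reading reported only as a limit remains possible. The estimated change is a 1.0-fold lower number from compound 2 to compound 3 (0.02 log units; within the scatter). Compound 3 is expected at 170000 nM, with an estimated range of 70000 nM to 350000 nM.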

Compound 3, half-maximal inhibitory concentration: > 200000 nM
Compound 3: a limit, no number; the forecaster's own chance of this, stated with the estimate: 35%; middle value at least 1.1-fold (0.07 log units) away from the limit.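

Methylsulfanyl ortho to a large group adds a second substituent that leaves the reading at the top of the range in this assay: compound 3 reads > 200000 nM, which is a limit and not a number. On these data alone, putting methylsulfanyl in place of hydrogen gives an at least 1.1-fold higher number from compound 2 to compound 3 (0.05 log units; that floor lies within the scatter), so the step cannot be told from the scatter, and its true size stays open. The step between compound 1 and compound 3 cannot be read, as both values are limits, so chloro and methylsulfanyl cannot be ordered, and the series now rests on one actual number, that of compound 2: the limit of > 200000 nM in this assay, at which 2 of the 3 values shown sit.

As far as these compounds go, the true values of compound 1 and compound 3 remain open, and with them whether either substituent changes the reading at all. Also open, from the compounds shown here alone, is how an amine or a carboxylic acid on this aromatic carbon, or a longer chain on the sulfur in place of methyl, would read in this assay.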